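Quinoline acid anilides: fluoro to trifluoromethyl on the anilide

The compounds below may be only part of what the source reports. "The series", "measured", "known", "first", "only" and "open" are said of these compounds alone.

Two members of the series carry a measurement. Compound 1 `COc1cc(-c2cc(C(=O)O)c3ccccc3n2)ccc1OCC(=O)Nc1ccccc1C` gives 0.8 in a physicochemical assay for lipophilicity, using the shake flask method, in phosphate buffer, measured as octanol-water partition, at pH 7.4; a higher number here means a more lipophilic compound, a lower number a more polar compound. Compound 2 `COc1cc(-c2cc(C(=O)O)c3ccccc3n2)ccc1OCC(=O)Nc1ccc(F)cc1` gives 1.1 in this assay. On these numbers compound 2 does not separate from compound 1: the step of a number 0.30 log units higher from compound 1 to compound 2 (within the scatter) lies within the scatter, so the two numbers show no difference that can be trusted.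

Compound 3 `COc1cc(-c2cc(C(=O)O)c3ccccc3n2)ccc1OCC(=O)Nc1ccc(C(F)(F)F)cc1` remains to be measured. The change is trifluoromethyl in place of fluoro on an aromatic carbon. No measured step touches this group: the only step shown, from compound 1 to compound 2, exchanges the whole anilide ring pattern rather than the group on that ring, and it does not bear on this change. The expectation therefore rests on the structural change alone, and a rise beyond the scatter is expected in this assay, by about a number 0.70 log units higher from compound 2 to compound 3 (beyond the scatter). For compound 3 the estimate in this assay is 1.8, in the range 1.3 to 2.4.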

Compound 3, distribution coefficient: 1.6
Compound 3: the middle estimate sits 0.20 log units above what was measured; measured number inside the range.
By their numbers in this assay, from the lowest: compounds 1 and 2 (each within the scatter of the next); then compound 3.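

Among the compounds shown here, at the aromatic carbon para to a large group, trifluoromethyl in place of fluoro gives the first step in this assay that clears the scatter, with a number 0.50 log units higher from compound 2 to compound 3 (beyond the scatter) as its size. Set against 2-methylphenyl on the amide-type nitrogen, 4-(trifluoromethyl)phenyl also clears it, at a number 0.80 log units higher from compound 1 to compound 3 (beyond the scatter), whereas 4-fluorophenyl in the same comparison did not. Nothing among the data available accounts for the size of either step.

A single matched pair leaves open whether the step from fluoro to trifluoromethyl would hold on another anilide ring pattern. On these data alone, how an amine, a nitrile or a longer chain at this same place would read in this assay also stays open.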